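The compounds below may be only part of what the source reports. "The series", "measured", "known", "first", "only" and "open" are said of these compounds alone.

The series shares one core. Compound 1 `Nc1nc(NC2CCCCC2)c2ncn(/C=C3/CC3(CO)CO)c2n1` carries a cyclohexylamino group on an aromatic carbon, compound 2 `CC(C)CSc1nc(N)nc2c1ncn2/C=C1/CC1(CO)CO` an isobutylsulfanyl group and compound 3 `CN(C)c1nc(N)nc2c1ncn2/C=C1/CC1(CO)CO` a dimethylamino group at that carbon. In an ADME assay on BCBL1 cells (Homo sapiens) for cytotoxicity, with a stated time of 7 days (on this read-out lower numbers stand for higher toxicity in this test and higher numbers for lower toxicity in this test), compound 1 gives > 20000 nM, a limit of the assay rather than a number. Compound 2 likewise gives > 20000 nM, again a limit. Compound 3 gives > 20000 nM, also a limit. Compound 2 thus stands at the limit, as do the other two values, which is the limit of > 20000 nM in this assay, at which 3 of the 3 values shown sit. The steps a step that the two limits leave unreadable from compound 1 to compound 2, a step that the two limits leave unreadable from compound 1 to compound 3 and a step that the two limits leave unreadable from compound 2 to compound 3 therefore cannot be sized. Compound 4 `CC(C)Sc1nc(N)nc2c1ncn2/C=C1/CC1(CO)CO` differs from compound 2 by isopropyl in place of isobutyl on a sulfur; cut one bond further out this reads isobutylsulfanyl to isopropylsulfanyl. For the measured compounds named here, no measured step gives a readable size for such a change; the three bear on it only in that each exchange at the aromatic carbon left the value at the limit. No step beyond the scatter is therefore expected, a step that the limit leaves unreadable from compound 2 to compound 4. Compound 4 is expected at 30000 nM, between 15000 nM and 80000 nM, most likely again reported as a limit.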

Compound 4, half-maximal cytotoxic concentration: > 20000 nM
Compound 4 ended at the assay's limit; the forecaster's own chance of this, stated with the estimate: 85%; the middle value lies beyond the limit too.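

For the compounds shown here, no step from compound 1, compound 2 or compound 3 to compound 4 can be read, since all four sit at one limit of the assay: the limit of > 20000 nM in this assay, at which 4 of the 4 values shown sit. The compounds shown leave open at what concentration any of them turns toxic in this assay, and whether the group on the aromatic carbon changes that concentration.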